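Methyl on the Amide Nitrogen: Expected Stability of Compound 4

A few compounds are considered here, and "the series" means these few. Any claim that something is new, unique, unknown or untested is made for them only; others in the source may bear on it.

Compound 1 `COc1c(/C=C/c2ccc(NS(C)(=O)=O)cc2)cc(N2CCC(=O)NC2=O)cc1C(C)(C)C`: 48.1%
Compound 2 `COc1c(CCc2ccc(NS(C)(=O)=O)cc2)cc(N2CCC(=O)NC2=O)cc1C(C)(C)C`: 2.5%
Compound 3 `COc1c(C(=O)Nc2ccc(NS(C)(=O)=O)cc2)cc(N2CCC(=O)NC2=O)cc1C(C)(C)C`: > 85%

Three compounds built on one shared core were tested in an ADME assay on microsomes from liver (Homo sapiens) for metabolic stability, with a stated time of 30 min; on this read-out lower numbers stand for a less stable compound and higher numbers for a more stable compound. Compound 1 gives 48.1%, and compound 2 gives 2.5%. Among the compounds with values here, compound 3 returns only a limit of the assay, > 85%, and it is the single compound sitting at the limit of > 85% in this assay, at which 1 of the 3 values shown sits. No two of these three differ in just one place, so none of the steps among them can be read as the effect of a single change.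

Compound 4 `COc1c(C(=O)N(C)c2ccc(NS(C)(=O)=O)cc2)cc(N2CCC(=O)NC2=O)cc1C(C)(C)C` differs from compound 3 by methyl in place of hydrogen on an amide-type nitrogen. Nothing measured here speaks to what such a change does, so the expectation rests on the high standing of compound 3 alone. A step beyond the usual scatter, downward from the limit, is what is expected for a number at least 17 percentage points lower from compound 3 to compound 4 (beyond the scatter), though a value still at the limit remains possible. Compound 4 is therefore expected to give about 68% in this assay, with a range from 35% to 90%.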

Compound 4, percent of the compound remaining in the liver assay: 64%
Compound 4: the middle estimate sits 4 percentage points above what was measured, within the range that was stated.
By their numbers in the liver assay, from the lowest: compound 2; then compound 1; then compound 4. At a limit, above all of these: compound 3.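

Within the data shown here, this pair is the first here that differs in one place, and so the first to show what this nitrogen tolerates. In the liver assay, methyl in place of hydrogen on an amide-type nitrogen gives a number at least 21 percentage points lower from compound 3 to compound 4 (beyond the scatter). This size is only a minimum, because compound 3 stands at a limit of the assay and not at a number: the limit of > 85% in the liver assay, at which 1 of the 4 values shown sits.

In a physicochemical assay for permeability, using PAMPA (on this read-out higher numbers stand for higher permeability and lower numbers for lower permeability), compound 3 gives 0.25 10^-6 cm/s and compound 4 gives 0.25 10^-6 cm/s, which is no change at the digits printed from compound 3 to compound 4 (within the scatter).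

The compounds shown leave open how an ethyl group or a longer chain on this same nitrogen would read in either assay. They also cannot tell whether the same methyl would give a similar step on the other cores shown, which carry no such nitrogen.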